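Swapping nitro for chloro on a hydrazone phenyl ring

The source may hold more compounds than are shown below. What is called first, only, known or untested is meant among the compounds shown, and "the series" means these compounds.

Of the compounds shown here, three of one family have been tested in a functional assay on the whole organism (strain Albino) with Mus musculus as the target, with a stated time of 0.5 h; on this read-out lower numbers stand for an effect already at smaller amounts and higher numbers for an effect only at larger amounts of compound. Compound 1 `C/C(=N/NC(=O)Nc1nc(-c2ccc(C)cc2)cc(-c2ccc(F)cc2)n1)c1ccc(Cl)cc1` gives 100 mg/kg. Compound 2 `COc1ccc(-c2cc(-c3ccc(F)cc3)nc(NC(=O)N/N=C(/C)c3ccc(C)cc3)n2)cc1` gives 300 mg/kg. Compound 3 `C/C(=N/NC(=O)Nc1nc(-c2ccc(C)cc2)cc(-c2ccc(Cl)cc2)n1)c1ccc([N+](=O)[O-])cc1` gives 300 mg/kg; this is level with compound 2 at the digits shown, the two together standing highest of the three, while compound 1 shows a lower number that lies beyond the usual scatter.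

Compound 4 `C/C(=N/NC(=O)Nc1nc(-c2ccc(C)cc2)cc(-c2ccc(Cl)cc2)n1)c1ccc(Cl)cc1` has not yet been measured. It differs from compound 3 in one place: chloro in place of nitro on an aromatic carbon. Among the compounds with values here, no measured pair in this set differs by exactly this change, so no step is known for it. Compound 1, which carries a chloro group at the same place on the hydrazone phenyl ring, gives 100 mg/kg, though it also differs from compound 3 elsewhere.

Because compound 1 gives 100 mg/kg, a move towards a lower number is expected for compound 4, estimated as a 2.0-fold lower number from compound 3 to compound 4 (0.30 log units; within the scatter). The value expected for compound 4 in this assay is 150 mg/kg, within a range from 60 mg/kg to 400 mg/kg.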

Compound 4, dose for half-maximal effect: 300 mg/kg
The estimate for compound 4 lay 2.0-fold (0.30 log units) below the measured number; low and high end bracket the measured number.
By their numbers in this assay, from the lowest: compound 1; then compounds 2, 3 and 4 (each within the scatter of the next).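

In this assay, putting 4-chlorophenyl in place of 4-nitrophenyl gives no change at the digits printed from compound 3 to compound 4 (within the scatter), so at this place the two groups cannot be told apart on this read-out. The chloro group here therefore does not bring the lower number of compound 1 on its own, and the one-place difference that does separate the two compounds lies elsewhere, where a fluoro group gives way to a chloro group, and this swap gives a 3.0-fold higher number from compound 1 to compound 4 (0.48 log units; beyond the scatter). Nothing measured here explains either result.

From the compounds shown here alone, whether an amine or a carboxylic acid at the place of the nitro group would give a different number remains open. Going by these compounds, it is also open whether the fluoro-to-chloro step keeps its size when the 4-chlorophenyl group is replaced by a different group.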